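Compound 4: swapping the aryl group on the amide

The compounds below may be only part of what the source reports. "The series", "measured", "known", "first", "only" and "open" are said of these compounds alone.

Compound 1 `O=C(CN1CCN(c2nnc(Cc3ccccc3)c3ccccc23)CC1)Nc1c(F)cccc1F`: 5490 nM
Compound 2 `O=C(CN1CCN(c2nnc(Cc3ccncc3)c3ccccc23)CC1)Nc1ccc(Br)cc1`: 19 nM
Compound 3 `COc1ccc(NC(=O)CN2CCN(c3nnc(Cc4ccccc4)c4ccccc34)CC2)cc1OC`: 32200 nM

In a functional assay on MDA-MB-231 cells (Homo sapiens) for cytotoxicity, read by MTT assay, with a stated time of 72 h (on this read-out higher numbers stand for weaker inhibition and lower numbers for stronger inhibition), compound 1 holds the middle place of the three numbers, with compound 3 higher and compound 2 far lower. Compound 4 `Cc1cccc(Cl)c1NC(=O)CN1CCN(c2nnc(Cc3ccccc3)c3ccccc23)CC1` is still unmeasured. It carries one change from compound 1: 2-chloro-6-methylphenyl in place of 2,6-difluorophenyl on an amide-type nitrogen. Among the compounds with values here, one measured step bears on this place, a 5.9-fold higher number from compound 1 to compound 3 (0.77 log units; beyond the scatter), and it is modest. Within the data shown here, compound 2 differs from compound 1 in more than one place, so it offers no clean step. With that single step as a guide, a shift no larger than it is expected, with no firm direction. The expected step is a 1.1-fold lower number from compound 1 to compound 4 (0.04 log units; within the scatter). Compound 4 is estimated at 5000 nM, within an expected range of 1200 nM to 20000 nM.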

Compound 4, half-maximal inhibitory concentration: 3920 nM
The estimate for compound 4 lay 1.3-fold (0.11 log units) above the measured number; the measured number falls inside the stated range.
By their numbers in this assay, from the lowest: compound 2; then compounds 4 and 1 (each within the scatter of the next); then compound 3.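

In this assay the exchange of 2,6-difluorophenyl for 2-chloro-6-methylphenyl on the amide-type nitrogen gives a 1.4-fold lower number from compound 1 to compound 4 (0.15 log units; within the scatter) and so leaves the two compounds alike. The second step, an 8.2-fold lower number from compound 3 to compound 4 (0.91 log units; beyond the scatter) on replacing 3,4-dimethoxyphenyl, shows that compound 4 stands apart from compound 3 just as compound 1 does. Nothing at hand accounts for either step.

Going by these compounds, how an unsubstituted phenyl or a 2,6-dimethylphenyl would read on this nitrogen remains open. So does the effect of an amine or a carboxylic acid on this aryl group.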